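Amine tail change in the series: compound 3 to compound 4

The compounds below may be only part of what the source reports. "The series", "measured", "known", "first", "only" and "open" are said of these compounds alone.

Measured so far:
- compound 1, `COc1c(OCCCCN2CCN(C)CC2)cc(O)c2c(=O)cc(-c3ccc(C)cc3)oc12`, in a functional assay on MCF7 cells (Homo sapiens) for cytotoxicity, read by MTT assay, with a stated time of 72 h (a lower number here means a stronger inhibitor, a higher number a weaker inhibitor), gives 4020 nM
- compound 2, `COc1c(OCCCCN2CCN(C)CC2)cc(O)c2c(=O)cc(-c3ccc(C(F)(F)F)cc3)oc12`, in this assay gives 2980 nM
- compound 3, `CCN(CC)CCCOc1c(OCc2ccccc2)cc(O)c2c(=O)cc(-c3ccccc3)oc12`, in this assay gives 3210 nM

Compound 3 stands second highest of the three numbers; its nearest neighbour is compound 2 and its furthest is compound 1, and both gaps lie within the scatter.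

Compound 4, `CN(C)CCCCOc1c(OCc2ccccc2)cc(O)c2c(=O)cc(-c3ccccc3)oc12`, differs from compound 3 in one place: (dimethylamino)methyl in place of diethylamino on a saturated chain carbon, three bonds along the chain from an oxygen on an aromatic ring.

Among the compounds with values here, the only measured single step, a 1.3-fold lower number from compound 1 to compound 2 (0.13 log units; within the scatter), concerns the aryl substituent, not the amine tail, so no measured step bears directly on this change. The three measured numbers sit close together, so no step beyond the scatter is expected; the estimated step is a 1.0-fold lower number from compound 3 to compound 4 (0.00 log units; within the scatter).

Compound 4 is therefore expected in this assay to give about 3200 nM, within a range of 1600 nM to 6400 nM.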

Compound 4, half-maximal inhibitory concentration: 3210 nM
Beside the measured number, compound 4's estimate is 1.0-fold (0.00 log units) below it, within the range that was stated.
By their numbers in this assay, from the lowest: compounds 2, 3, 4 and 1 (each within the scatter of the next).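

In this assay, the tail change from 3-(diethylamino)propyl to 4-(dimethylamino)butyl gives no change at the digits printed from compound 3 to compound 4 (within the scatter), the first single-place step read on the amine tail rather than the aryl substituent. For this pair, the chain and its amine can thus change together without a readable shift in the number. No measurement bearing on the reason for this result is available.

Because chain and amine differ together, the pair cannot separate them; a 3-(dimethylamino)propyl or 4-(diethylamino)butyl tail would do so. Going by these compounds, a carboxylic acid at the chain end also remains open.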